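The source may hold more compounds than are shown below. What is called first, only, known or untested is meant among the compounds shown, and "the series" means these compounds.

Compound 1 `NC(=O)c1c(NC(=O)c2ccccc2Cl)sc2c1CCN(Cc1ccccc1)C2`, compound 2 `NC(=O)c1c(NC(=O)c2ccccc2Cl)sc2c1CCN(C(=S)Nc1ccccc1)C2` and compound 3 `NC(=O)c1c(NC(=O)c2ccccc2Cl)sc2c1CCN(C(=S)Nc1ccccc1F)C2` share one core and differ only in the group on the amine nitrogen in a ring. In a functional assay on MKN-74 cells (Homo sapiens) for antiproliferative activity, with a stated time of 24 h (on this read-out lower numbers stand for stronger inhibition and higher numbers for weaker inhibition), compound 1 gives 14500 nM, compound 2 gives 15600 nM and compound 3 gives 12600 nM. The steps between them are all small: a 1.1-fold higher number from compound 1 to compound 2 (0.03 log units; within the scatter), a 1.2-fold lower number from compound 1 to compound 3 (0.06 log units; within the scatter) and a 1.2-fold lower number from compound 2 to compound 3 (0.09 log units; within the scatter). Compound 3 therefore stands together with compound 1 and compound 2 inside the scatter, and none of the three is set apart from the others.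

Compound 4 `NC(=O)c1c(NC(=O)c2ccccc2C(F)(F)F)sc2c1CCN(C(=S)Nc1ccccc1F)C2` keeps the group on the amine nitrogen of compound 3 and alters the other end of the molecule: trifluoromethyl in place of chloro on an aromatic carbon. Going by the values given here, none of the three measured steps touches this part; compound 1, compound 2 and compound 3 all carry the same 2-chlorophenyl, so there is no measured step that bears on this exchange. Among the compounds with values here, the only steps known are those on the amine nitrogen, and they were all within the scatter. With nothing pointing in either direction, compound 4 is expected to stay close to compound 3, giving a step of a 1.1-fold lower number from compound 3 to compound 4 (0.02 log units; within the scatter) in this assay. Compound 4 is accordingly estimated at 12000 nM, with a range from 4000 nM to 36000 nM.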

Compound 4, half-maximal inhibitory concentration: 19600 nM
Compound 4: the middle estimate sits 1.6-fold (0.21 log units) below what was measured, within the range that was stated.
By their numbers in this assay, from the lowest: compounds 3, 1, 2 and 4 (each within the scatter of the next).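

Chloro giving way to trifluoromethyl is the first measured change at this end of the molecule, and in this assay the exchange gives a 1.6-fold higher number from compound 3 to compound 4 (0.19 log units; within the scatter) and so stays within the scatter. This place, on an aromatic carbon ortho to a large group, therefore joins the amine nitrogen in a ring: neither has yet produced a measured step beyond the scatter, even though a group of four heavy atoms here replaces a single heavy atom. No measured evidence is available to explain how this exchange acts on the read-out.

Going by these compounds alone, this single exchange, read against only one group on the amine nitrogen, leaves open how other groups at the same place would read, among them methoxy, an amine, a carboxylic acid or simply hydrogen. From the compounds shown here alone, it also remains open whether 2-(trifluoromethyl)phenyl would stay within the scatter when paired with the group that compound 1 carries on the amine nitrogen, or whether the two ends of the molecule act independently of each other.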